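This account rests on a few compounds, and the source may have more. Where it says the series, first, only, none or still open, it means among the compounds named here.

Among the compounds with values here, in a functional assay on HeLa cells (Homo sapiens) for inhibition, read by CCK-8 assay, with a stated time of 48 h (a lower number here means a stronger inhibitor, a higher number a weaker inhibitor), compound 2 `O=C(NCCNS(=O)(=O)c1ccc(-c2ccccc2OCc2cccc(O)c2)s1)Nc1cc(C(F)(F)F)cc(C(F)(F)F)c1` gives 17300 nM, the only true number in this small set. Compound 1 `O=C(NCCNS(=O)(=O)c1ccc(-c2ccccc2O[C@H]2CC[C@H](O)CC2)s1)Nc1cc(C(F)(F)F)cc(C(F)(F)F)c1` reads > 20000 nM, which is a limit of the assay and not a number. Compound 3 `O=C(NCCNS(=O)(=O)c1ccc(-c2ccccc2Oc2ccc([N+](=O)[O-])c([N+](=O)[O-])c2)s1)Nc1cc(Cl)cc(Cl)c1` reads > 20000 nM, again a limit.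

The next structure is compound 4 `Nc1ccc(Oc2ccccc2-c2ccc(S(=O)(=O)NCCNC(=O)Nc3cc(C(F)(F)F)cc(C(F)(F)F)c3)s2)cc1`, with the change (4-aminophenyl in place of 3-hydroxybenzyl on an oxygen on an aromatic ring). In words, 4-aminophenyl stands in place of 3-hydroxybenzyl on an oxygen on an aromatic ring, while the rest of compound 2 is kept.

One measured step changes the group at this same place: an at least 1.1-fold lower number from compound 1 to compound 2 (0.06 log units; that floor lies within the scatter). It stays within the scatter and is bounded on one side only, so it shows no sensitivity to the group at this place, though it cannot exclude one. Within the data shown here, no measured step covers the entry of 4-aminophenyl itself, and compound 3 is joined to the others by no single-place step.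

In this assay no shift beyond the scatter is therefore expected, and the expected change is a 1.2-fold lower number from compound 2 to compound 4 (0.06 log units; within the scatter). A reading at the limit of > 20000 nM in this assay, at which 2 of the 3 values shown sit, would be no surprise for compound 4.

For compound 4 the estimated value is 15000 nM, with an expected range from 6000 nM to 30000 nM.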

Compound 4, half-maximal inhibitory concentration: > 20000 nM
Compound 4: only a limit was reported; the forecaster's own chance of this, stated with the estimate: 40%; middle value at least 1.3-fold (0.12 log units) away from the limit.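

In this assay the change from (3-hydroxybenzyl)oxy to 4-aminophenoxy reads an at least 1.1-fold higher number from compound 2 to compound 4 (0.06 log units; that floor lies within the scatter), so this second step at the oxygen is also bounded on one side only and shows no shift beyond the scatter, though it cannot exclude one. The step joining compound 1 and compound 4 cannot be read, as both readings are limits. Within the data shown here, compound 4 adds a further limit, not a number, and now a carbon-only aromatic ring bearing an amine has been tested at this place alongside the 3-hydroxybenzyl and 4-hydroxycyclohexyl groups, leaving compound 2 as the only true number: the limit of > 20000 nM in this assay, at which 3 of the 4 values shown sit.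

The step to compound 4 replaces the benzyl link and swaps the hydroxyl for an amine in a single change, so the two cannot be separated here. On these data alone, whether a carboxylic acid or a longer chain such as phenethyl on this oxygen would give a reading clearly apart from that of compound 2 in this assay stays open.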